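The source may report more compounds than this note shows. Statements on the series, on what has been measured and on what is new or still open speak of the compounds shown alone.

Series notes, step from compound 1 to compound 4.

Compound 1 `Cn1c(-c2ccccc2)nc2c(NC3CCCC3)ncnc21` is the phenyl parent of the set. Among the measured compounds shown here, in an assay on CHO cells for displacement of a labelled ligand from adenosine receptor A3 (Homo sapiens), read by scintillation counting, with a stated time of 3 h (on this read-out lower numbers stand for stronger inhibition and higher numbers for weaker inhibition), compound 1 gives 846 nM, the second highest of the three numbers so far. Compound 2 `Cn1c(-c2ccc(O)cc2)nc2c(NC3CCCC3)ncnc21` gives 521 nM; the step of a 1.6-fold lower number from compound 1 to compound 2 (0.21 log units; within the scatter) is within the scatter. Compound 3 `Cn1c(-c2cccnc2)nc2c(NC3CCCC3)ncnc21` gives 11000 nM; the step of a 13-fold higher number from compound 1 to compound 3 (1.11 log units; beyond the scatter) is large and beyond the scatter, as is a 21-fold higher number from compound 2 to compound 3 (1.32 log units; beyond the scatter).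

Compound 4 `Cn1c(-c2ccc(Cl)cc2)nc2c(NC3CCCC3)ncnc21` differs from compound 1 by chloro in place of hydrogen on an aromatic carbon. For the measured compounds named here, no measured step introduces a chloro group, so the closest guidance is indirect: the hydroxy step a 1.6-fold lower number from compound 1 to compound 2 (0.21 log units; within the scatter) shows that a substituent at this position on the carbon-only ring can be carried without a change beyond the scatter, whereas only the ring swap to pyridin-3-yl a 13-fold higher number from compound 1 to compound 3 (1.11 log units; beyond the scatter) moved the number far. A chloro group keeps the carbon-only ring, so the expectation is a step of the size of a 1.4-fold lower number from compound 1 to compound 4 (0.15 log units; within the scatter), within the scatter. The estimate for compound 4 is 600 nM, with an expected range from 200 nM to 2000 nM.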

Compound 4, inhibition constant: 1210 nM
Compound 4: middle estimate off by 2.0-fold (0.30 log units), on the low side; measured number inside the range.
By their numbers in this assay, from the lowest: compounds 2, 1 and 4 (each within the scatter of the next, the first and the last beyond it); then compound 3.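

In this assay, chloro on the aromatic carbon para to a large group is carried with no change beyond the scatter (a 1.4-fold higher number from compound 1 to compound 4 (0.16 log units; within the scatter)), so compound 4 joins compound 2 in keeping the number of the phenyl parent despite a new substituent. The choice of substituent still registers between the two substituted compounds (a 2.3-fold higher number from compound 2 to compound 4 (0.37 log units; beyond the scatter)), although neither is separated from compound 1. Among the compounds shown here, the 4-chlorophenyl group also stays clearly apart from the pyridin-3-yl group (a 9.1-fold lower number from compound 3 to compound 4 (0.96 log units; beyond the scatter)), leaving compound 3 as the only compound beyond the scatter of all the others.

On these data alone, whether an amine or a carboxylic acid at this place would stay with compound 1, compound 2 and compound 4 remains open. No supporting data accompany these results to explain the steps.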